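The source may hold more compounds than are shown below. What is called first, only, known or untested is meant among the compounds shown, and "the series" means these compounds.

For the measured compounds named here, compound 3 `N#CC1=C(N)N(c2ccc(S(N)(=O)=O)cc2)C2=C(C(=O)CCC2)C1c1ccc(Cl)cc1Cl` gives 65% in a functional assay on Ehrlich cells (Mus musculus) for antiproliferative activity, read by trypan blue exclusion, with a stated time of 2 h, tested at 50 ug/mL (a lower number here means a weaker effect, a higher number a stronger effect of the compound at the concentration tested), the second highest of the three numbers known so far. Compound 2 `N#CC1=C(N)N(c2ccc(S(N)(=O)=O)cc2)C2=C(C(=O)CCC2)C1c1ccc([N+](=O)[O-])cc1` gives 95%, and compound 1 `N#CC1=C(N)N(c2ccc(S(N)(=O)=O)cc2)C2=C(C(=O)CCC2)C1/C=C/c1ccccc1` gives 40%; the steps of a number 25 percentage points higher from compound 1 to compound 3 (beyond the scatter) and a number 30 percentage points lower from compound 2 to compound 3 (beyond the scatter) show that the group on this saturated ring carbon moves the read-out by modest to large amounts. Compound 4 `COc1ccc(C2C(C#N)=C(N)N(c3ccc(S(N)(=O)=O)cc3)C3=C2C(=O)CCC3)c2ccccc12` differs from compound 3 by 4-methoxynaphthalen-1-yl in place of 2,4-dichlorophenyl on a saturated ring carbon. Going by the values given here, no measured step involves a 4-methoxynaphthalen-1-yl group, so the direction is open; a step of either sign beyond the scatter is plausible. The estimate for compound 4 is 70%, between 45% and 95%, implying a number 5 percentage points higher from compound 3 to compound 4 (within the scatter) in this assay.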

Compound 4, a percentage reported as activity, at one concentration (the size of the read-out at that concentration, not a potency): 30%
The estimate for compound 4 lay 40 percentage points above the measured number; the measured number lies below the stated range.
By their numbers in this assay, from the lowest: compounds 4 and 1 (each within the scatter of the next); then compound 3; then compound 2.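

In this assay, the 4-methoxynaphthalen-1-yl group on this saturated ring carbon gives a number 35 percentage points lower from compound 3 to compound 4 (beyond the scatter) and a number 65 percentage points lower from compound 2 to compound 4 (beyond the scatter), so an aromatic ring at this position does not by itself keep the read-out high. The two substituted phenyl groups had both stood clear of 2-phenylethenyl, whereas this two-ring group gives a number 10 percentage points lower from compound 1 to compound 4 (within the scatter). No measurement at hand explains this change. The compounds shown leave open whether the methoxy group or the second ring goes with the lower number, which 4-methoxyphenyl and unsubstituted naphthalen-1-yl would separate. As far as these compounds go, how a 4-aminophenyl group would read at this position also remains open.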